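This account rests on a few compounds, and the source may have more. Where it says the series, first, only, none or still open, it means among the compounds named here.

Measured compounds in a functional assay on SMMC-7721 cells (Homo sapiens) for cytotoxicity, read by MTT assay, with a stated time of 24 h; a higher number here means a weaker inhibitor, a lower number a stronger inhibitor:
- compound 1 `CC(=O)Nc1ccc(S(=O)(=O)N2C/C(=C\c3ccccc3F)C(=O)/C(=C/c3ccccc3F)C2)cc1`: 7500 nM
- compound 2 `O=C1/C(=C/c2ccc(F)cc2)CN(S(=O)(=O)c2ccccc2)C/C1=C\c1ccc(F)cc1`: 9100 nM
- compound 3 `Cc1ccc(S(=O)(=O)N2C/C(=C\c3ccc(F)cc3)C(=O)/C(=C/c3ccc(F)cc3)C2)cc1`: 5000 nM

All three share one core and differ only in the substituent on the sulfonyl-bearing phenyl ring and in the position of the fluorine on the arylidene rings. Compound 3 sits in one band with compound 1 and compound 2: neither gap reaches beyond the scatter, so no ranking among the three is supported. Within the data shown here, the one step measured at the sulfonyl-bearing phenyl ring is a 1.8-fold lower number from compound 2 to compound 3 (0.26 log units; within the scatter), which stays within the scatter.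

Compound 4 `O=C1/C(=C/c2ccc(F)cc2)CN(S(=O)(=O)c2ccc(O[N+](=O)[O-])cc2)C/C1=C\c1ccc(F)cc1` is the next member. Relative to compound 3 the change is nitrooxy in place of methyl on an aromatic carbon. Among the measured compounds shown here, the only step that bears on this position, from compound 2 to compound 3, was within the scatter, and no measured pair tells how a nitrooxy group behaves at this site. With the substituent at the same place and the rest of the molecule unchanged, a step of this assay beyond the scatter is not expected in either direction. The expected step is a 1.1-fold higher number from compound 3 to compound 4 (0.04 log units; within the scatter), that is, none beyond the scatter. Compound 4 is estimated at 5500 nM, with a range from 2500 nM to 12000 nM.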

Compound 4, half-maximal inhibitory concentration: 5000 nM
Estimate against measurement, compound 4: 1.1-fold (0.04 log units) above; the range from low to high includes it.
By their numbers in this assay, from the lowest: compounds 3, 4, 1 and 2 (each within the scatter of the next).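

In this assay, the position para to a large group on the sulfonyl-bearing phenyl ring now has three substituents compared on an otherwise unchanged molecule: hydrogen, methyl and nitrooxy. The entering nitrooxy group has 4 heavy atoms and 3 hydrogen-bond acceptors, against 1 heavy atom and no acceptor for methyl, yet the read-out stays flat, with the exchange for methyl giving (no change at the digits printed from compound 3 to compound 4 (within the scatter)) and the exchange for hydrogen giving (a 1.8-fold lower number from compound 2 to compound 4 (0.26 log units; within the scatter)), so a substituent of quite different make-up at this site has produced no step beyond the scatter. No measurement on hand accounts for this flat result.

Going by these compounds, whether an amine, a carboxylic acid or a longer chain at this position would give a step beyond the scatter remains open, since only hydrogen, methyl and nitrooxy can be compared here. Steps involving compound 1 cannot be read, as it differs from the others in two places, so the separate contributions of the acetamide-bearing ring and of the fluorine position on the arylidene rings also remain unresolved.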